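This account rests on a few compounds, and the source may have more. Where it says the series, first, only, none or still open, it means among the compounds named here.

Measured so far in a functional assay on MCF7 cells (Homo sapiens) for inhibition, read by sulforhodamine B assay, with a stated time of 48 h; on this read-out higher numbers stand for weaker inhibition of growth and lower numbers for stronger inhibition of growth:
Compound 1 `CC1(/C=C/c2ccc(F)cc2)C=CC(=O)O1`: 38500 nM
Compound 2 `COc1cc(/C=C/C2(C)C=CC(=O)O2)cc(OC)c1OC`: 56600 nM
Compound 3 `COc1cc(OC)c(/C=C/C2(C)C=CC(=O)O2)c(OC)c1`: 102000 nM

Among these three, compound 1 at 38500 nM lies within the scatter of compound 2, while compound 3 has a number higher than that of compound 1 by more than the scatter. Compound 4 `COc1ccc(/C=C/C2(C)C=CC(=O)O2)cc1`, not yet measured in this assay, keeps the core of compound 1 and carries methoxy in place of fluoro on an aromatic carbon.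

For the measured compounds named here, no measured pair isolates a single change, so this swap has no direct precedent in the data. Compound 2 at 56600 nM and compound 3 at 102000 nM both carry methoxy groups and both have numbers higher than compound 1, which points weakly upward. The expected change is therefore small and upward, and none beyond the scatter is anticipated. The estimated step is a 1.3-fold higher number from compound 1 to compound 4 (0.11 log units; within the scatter). Compound 4 is expected at about 50000 nM, with an estimated range from 25000 nM to 100000 nM.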

Compound 4, concentration for total growth inhibition: 183000 nM
The estimate for compound 4 lay 3.7-fold (0.56 log units) below the measured number; the whole stated range lies below it.
By their numbers in this assay, from the lowest: compounds 1, 2, 3 and 4 (each within the scatter of the next, the first and the last beyond it).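

In this assay, for the compounds shown here, methoxy in place of fluoro on an aromatic carbon, para to a group of 9 heavy atoms, gives a 4.8-fold higher number from compound 1 to compound 4 (0.68 log units; beyond the scatter) and is the first single change that can be read in this set. It shows that this position is not indifferent to the group it carries: with the core of compound 1 kept, the swap alone moves the number beyond the scatter, toward weaker inhibition of growth. Nothing measured here accounts for the size or direction of this step.

With only fluoro and methoxy seen at this place, the compounds shown leave open whether either group departs from the plain hydrogen. Chloro, hydroxyl or an amine at the same position would show whether the rise belongs to methoxy alone or extends to other groups.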